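This account rests on a few compounds, and the source may have more. Where it says the series, first, only, none or still open, it means among the compounds named here.

Measured compounds:
`COc1cc(C(=O)O)ccc1OCCCCOc1ccc(C(=O)C(C)C)c(O)c1C` compound 1, 73.1%
`Cc1c(OCCCCOc2cccc(C(=O)O)c2)ccc(C(=O)CC2CCCC2)c1O` compound 2, 80.6%
`Cc1cc(C(=O)O)ccc1OCCCCOc1ccc(C(=O)C(C)C)c(O)c1C` compound 3, 76.9%

In an assay on HEK293 cells for positive allosteric modulation of metabotropic glutamate receptor 2 (Rattus norvegicus), read by thallium flux, with a stated time of 2.5 min (a higher number here means a larger maximal response, a lower number a smaller maximal response), compound 1 stands lowest of the three numbers, though both others lie within the scatter of it: compound 3 is the nearest, and compound 2 the furthest, with neither gap large enough to speak of an order.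

Compound 4 is `COc1cc(C(=O)O)ccc1OCCCCOc1ccc(C(=O)CC(C)(C)C)c(O)c1C`. It differs from compound 1 by neopentyl in place of isopropyl on a carbonyl carbon. Among the measured compounds shown here, the one step recorded between measured compounds, a number 3.8 percentage points higher from compound 1 to compound 3 (within the scatter), concerns a change on the aromatic carbon, not the carbonyl, and does not bear directly on this step. For the measured compounds named here, compound 2 carries a larger group on the carbonyl carbon than compound 1, but it also differs elsewhere, so its two values show only that such a pair lies within the scatter of one another.

Nothing in the measured data points to a step beyond the scatter for this change, so compound 4 is expected to give 76%, between 62% and 90%, which means an expected step of a number 2.9 percentage points higher from compound 1 to compound 4 (within the scatter).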

Compound 4, largest response reached (reported as percent of maximum), in percent of the reference or control that the assay uses: 98.6%
Compound 4: middle estimate off by 22.6 percentage points, on the low side; measured number above the stated range.
By their numbers in this assay, from the lowest: compounds 1, 3 and 2 (each within the scatter of the next); then compound 4.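

The carbonyl carbon proves to be a place where the group matters: in this assay neopentyl in place of isopropyl gives a number 25.5 percentage points higher from compound 1 to compound 4 (beyond the scatter) and is the only step shown that leaves the scatter, unlike methyl in place of methoxy on an aromatic carbon with a number 3.8 percentage points higher from compound 1 to compound 3 (within the scatter) on the same core. The change from isopropylcarbonyl to neopentylcarbonyl adds carbon only, with no ring, no hydrogen-bond donor or acceptor and no net charge, so a purely carbon change at this position is enough to raise the largest response reached. No measurement at hand accounts for the size of this step.

On these data alone, whether the same change carries over to the core of compound 3 stays open. So does what a longer chain, a cyclohexyl group or an amine on this carbonyl carbon would give.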